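Swapping trifluoromethyl for chloro on the urea-linked ring

The source may hold more compounds than are shown below. What is called first, only, known or untested is meant among the compounds shown, and "the series" means these compounds.

Among the compounds with values here, in a functional assay on A549 cells (Homo sapiens) for inhibition, read by sulforhodamine B assay, with a stated time of 48 h (a lower number here means that less compound is tolerated, a higher number that more compound is tolerated), compound 2 `COc1cc2cc(Oc3ccc(NC(=O)Nc4ccc(Cl)c(C(F)(F)F)c4)cc3)c(C)nc2cc1OC` gives 15100 nM, the lower of the two numbers measured so far, though within the scatter of compound 1 `COc1cc2cc(Oc3ccc(NC(=O)Nc4cccc(C(F)(F)F)c4)cc3)c(C)nc2cc1OC`, which in this assay gives 26600 nM. Compound 3 `COc1cc2cc(Oc3ccc(NC(=O)Nc4ccc(Cl)c(Cl)c4)cc3)c(C)nc2cc1OC` differs from compound 2 by chloro in place of trifluoromethyl on an aromatic carbon. Within the data shown here, the only measured step, a 1.8-fold lower number from compound 1 to compound 2 (0.25 log units; within the scatter), changed the same ring and stayed within the scatter, so no step beyond the scatter is expected from this swap either. Compound 3 is therefore estimated at about 18000 nM, in a range from 8000 nM to 40000 nM, which amounts to an expected step of a 1.2-fold higher number from compound 2 to compound 3 (0.08 log units; within the scatter).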

Compound 3, concentration lethal to 50% of the cells: 28300 nM
Compound 3: middle estimate off by 1.6-fold (0.20 log units), on the low side; the measured number falls inside the stated range.
By their numbers in this assay, from the lowest: compounds 2, 1 and 3 (each within the scatter of the next).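

In this assay, chloro in place of trifluoromethyl at this position gives a small step (a 1.9-fold higher number from compound 2 to compound 3 (0.27 log units; within the scatter)), so these two groups cannot be told apart here. The change of the whole ring substituent pattern, 3,4-dichlorophenyl in place of 3-(trifluoromethyl)phenyl, also gives no step beyond the scatter (a 1.1-fold higher number from compound 1 to compound 3 (0.03 log units; within the scatter)). Nothing available explains why these groups read alike. Going by these compounds, it remains open whether an amine or a carboxylic acid at this position would give a step beyond the scatter.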